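Shifting the Hydroxyl Group of Compound 2

This account rests on a few compounds, and the source may have more. Where it says the series, first, only, none or still open, it means among the compounds named here.

Of the compounds shown here, three built on one shared core have been tested in a functional assay, read by spectrophotometry, with a stated time of 1 h; a higher number here means a weaker inhibitor, a lower number a stronger inhibitor. Compound 1 `O=c1[nH]c2ccccc2cc1/C=N/Cc1ccccc1` gives 3140000 nM. Compound 2 `Cc1ccc2[nH]c(=O)c(/C=N/c3ccccc3O)cc2c1` gives 1350000 nM, the lowest of the three numbers and so the strongest inhibitor in the set. Compound 3 `NS(=O)(=O)CC(=O)N/N=C/c1cc2ccccc2[nH]c1=O` gives 8730000 nM, the highest. Compound 2 stands apart from compound 1 by a gap that lies beyond the usual scatter, and from compound 3 by a wider gap, also beyond the scatter.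

The next compound, compound 4 `Cc1ccc2[nH]c(=O)c(/C=N/c3ccc(O)cc3)cc2c1`, has not yet been measured in this assay. It keeps every atom of compound 2 but joins them differently: 4-hydroxyphenyl in place of 2-hydroxyphenyl on a double-bonded nitrogen. The hydroxyl group stays on the phenyl ring, and the ring stays on the double-bonded nitrogen.

Among the measured compounds shown here, no pair of measured compounds differs in just one place, so there is no measured step to lean on. A change of this kind, keeping the same atoms and the same donor and acceptor count, is expected to shift the number only a little, and the step of a 1.1-fold higher number from compound 2 to compound 4 (0.05 log units; within the scatter) is estimated to stay within the usual scatter, in no firm direction. Compound 4 is therefore expected to give about 1500000 nM in this assay, with a range from 500000 nM to 5000000 nM.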

Compound 4, half-maximal inhibitory concentration: "not active" (no number reported)
No number was reported for compound 4; there is nothing to compare the estimate with.
By their numbers in this assay, from the lowest: compound 2; then compound 1; then compound 3.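

Among the compounds shown here, compound 4 is reported as "not active" in this assay, without a number, and no step from compound 2 to compound 4 can be read. No measured evidence bears on this result. The compounds shown leave open how far, if at all, 4-hydroxyphenyl in place of 2-hydroxyphenyl changes inhibition.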